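This account rests on a few compounds, and the source may have more. Where it says the series, first, only, none or still open, it means among the compounds named here.

In an assay with Cholecystokinin receptor type A (Rattus norvegicus) as the target (a higher number here means a weaker inhibitor, a lower number a stronger inhibitor), compound 1 `O=C1NN(C(=S)Nc2ccc(Cl)c(C(F)(F)F)c2)C(c2ccccc2)C1c1ccccc1` gives 42 nM, while compound 2 `O=C1NN(C(=S)Nc2ccc(Cl)c(C(F)(F)F)c2)[C@H](c2ccccc2)[C@H]1c1ccccc1` gives 17 nM, the lower of the two numbers measured. The change a 2.5-fold lower number from compound 1 to compound 2 (0.39 log units; beyond the scatter) goes with the fact that one of compounds 1 and 2 is drawn with a defined configuration and the other without, at the place where they differ, since compound 2 is a single drawn form of compound 1. Compound 3 `O=C1NN(C(=S)Nc2ccc(Cl)c(C(F)(F)F)c2)[C@@H](c2ccccc2)[C@@H]1c1ccccc1` differs from compound 2 in this way: the two compounds have the same atoms and bonds and differ only in configuration as drawn: 2 of 2 stereo elements differ (all stereocentres are inverted: mirror images); a stereocentre at a saturated ring carbon is drawn S in compound 2 and R in compound 3; a stereocentre at a saturated ring carbon is drawn R in compound 2 and S in compound 3. Among the compounds with values here, only that one measured step bears on it; because one drawn form gave a 2.5-fold lower number from compound 1 to compound 2 (0.39 log units; beyond the scatter), the mirror image is expected to be weaker, an upward step an 18-fold higher number from compound 2 to compound 3 (1.25 log units; beyond the scatter). The estimate for compound 3 is 300 nM, ranging from 60 nM to 3000 nM.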

Compound 3, half-maximal inhibitory concentration: 810 nM
Beside the measured number, compound 3's estimate is 2.7-fold (0.43 log units) below it; the measured number falls inside the stated range.
By their numbers in this assay, from the lowest: compound 2; then compound 1; then compound 3.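

The mirror images are far apart, a 48-fold higher number from compound 2 to compound 3 (1.68 log units; beyond the scatter), so the arrangement at the two saturated ring carbons strongly affects the reading even with identical atoms and bonds. The inverted form also reads well above the form drawn without configuration, a 19-fold higher number from compound 1 to compound 3 (1.29 log units; beyond the scatter). The large gap between the mirror images can be tied to one difference: the fact that compounds 2 and 3 differ only in the configuration as drawn.

On these data alone, whether this preference would survive replacing a phenyl group with a carboxylic acid remains open. So does the reading for the other pair of mirror images, with only one ring carbon inverted.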